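Three Measured Ester Amines and a Fourth Still Expected

The compounds below may be only part of what the source reports. "The series", "measured", "known", "first", "only" and "open" are said of these compounds alone.

Compound 1 `CCCCN(CCCC)CCC(=O)O[C@@H]1C[C@@H]2CC[C@@]1(C)C2(C)C`: 41800 nM
Compound 2 `CN1CCN(CCC(=O)O[C@@H]2C[C@@H]3CC[C@@]2(C)C3(C)C)CC1`: 48100 nM
Compound 3 `CCN1CCN(CC(=O)O[C@@H]2C[C@@H]3CC[C@@]2(C)C3(C)C)CC1`: 100000 nM

In an ADME assay on MDCK cells (Canis lupus familiaris) for cytotoxicity, read by MTT assay, with a stated time of 48 h (on this read-out higher numbers stand for lower toxicity in this test and lower numbers for higher toxicity in this test), compound 3 gives the highest number of the three; compound 2 sits nearest and compound 1 furthest, and both gaps lie beyond the usual scatter. Compound 4 `CC1(C)[C@H]2CC[C@]1(C)[C@H](OC(=O)CN1CCNCC1)C2` has not yet been measured. It differs from compound 3 in one place: hydrogen in place of ethyl on an amine nitrogen in a ring. Among the measured compounds shown here, no measured pair shows this same change, so its size cannot be read off from the data. Since compound 3 already gives 100000 nM and the three measured numbers sit close together, the step is expected to be small or none beyond the scatter. For compound 4, the estimated value in this assay is 100000 nM, with a range from 50000 nM to 200000 nM. The expected step of no change at the digits printed from compound 3 to compound 4 (within the scatter) is thus estimated to stay within the scatter.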

Compound 4, half-maximal cytotoxic concentration: 51600 nM
Estimate against measurement, compound 4: 1.9-fold (0.29 log units) above; low and high end bracket the measured number.
By their numbers in this assay, from the lowest: compounds 1, 2, 4 and 3 (each within the scatter of the next, the first and the last beyond it).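

Among the compounds shown here, on this assay, the change of ethyl to hydrogen on this ring nitrogen gives a 1.9-fold lower number from compound 3 to compound 4 (0.29 log units; within the scatter), the first comparison here of compounds that differ in one place. At this position, then, the ethyl group can be removed without a step that stands clear of the usual scatter. Nothing measured here offers an explanation for this small step. Still open, as far as these compounds go, is whether a larger group on this ring nitrogen, such as benzyl or acetyl, would behave the same way. From the compounds shown here alone, whether the same change would give a similar step on another core also remains unknown.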